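This account rests on a few compounds, and the source may have more. Where it says the series, first, only, none or still open, it means among the compounds named here.

Three compounds have been measured in an ADME assay for permeability, using PAMPA, with a stated time of 30 min, at pH 7.4; a higher number here means that the compound crosses the layer faster, a lower number that the compound crosses the layer more slowly:

Compound 1 `COc1cccc(CNCCCNc2ccnc3cc(Cc4cc(C)cc(C)c4)ccc23)c1O`: 23 10^-6 cm/s
Compound 2 `COc1cccc(CNCCCNc2ccnc3cc(Cc4ccc(F)cc4)ccc23)c1O`: 23 10^-6 cm/s
Compound 3 `COc1ccc(F)cc1CNCCCNc1ccnc2cc(Cc3ccc(F)cc3)ccc12`: 23 10^-6 cm/s

Compound 1 differs from compound 2 by 3,5-dimethylphenyl in place of 4-fluorophenyl on a saturated chain carbon bound to an aromatic carbon, and that change gave no change at the digits printed from compound 2 to compound 1 (within the scatter). Compound 3 differs from compound 2 in its core by 5-fluoro-2-methoxyphenyl in place of 2-hydroxy-3-methoxyphenyl on a saturated chain carbon bound to an amine nitrogen, and that change gave no change at the digits printed from compound 2 to compound 3 (within the scatter). Compound 4 `COc1ccc(F)cc1CNCCCNc1ccnc2cc(Cc3cc(C)cc(C)c3)ccc12` has not yet been measured. It differs from compound 3 by 3,5-dimethylphenyl in place of 4-fluorophenyl on a saturated chain carbon bound to an aromatic carbon, the same change that was made from compound 2 to compound 1, at a place described in the same words. Because that earlier step was no change at the digits printed from compound 2 to compound 1 (within the scatter), the step in this assay is expected to be no change at the digits printed from compound 3 to compound 4 (within the scatter). Compound 4 is therefore estimated at 23 10^-6 cm/s, expected to fall between 14 10^-6 cm/s and 36 10^-6 cm/s.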

Compound 4, apparent permeability: 23 10^-6 cm/s
Estimate against measurement, compound 4: no gap at the digits printed; low and high end bracket the measured number.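

In this assay, 3,5-dimethylphenyl in place of 4-fluorophenyl gave no change at the digits printed from compound 3 to compound 4 (within the scatter), and this matched the earlier step on the other core: the same change on two cores in this assay, no change at the digits printed (within the scatter) from compound 2 to compound 1 and no change at the digits printed (within the scatter) from compound 3 to compound 4, 1.0-fold (0.00 log units) apart, within the scatter of two such steps. Likewise, 5-fluoro-2-methoxyphenyl in place of 2-hydroxy-3-methoxyphenyl gave no change at the digits printed from compound 1 to compound 4 (within the scatter), again matching its earlier step: the same change on two cores in this assay, no change at the digits printed (within the scatter) from compound 2 to compound 3 and no change at the digits printed (within the scatter) from compound 1 to compound 4, 1.0-fold (0.00 log units) apart, within the scatter of two such steps. Each change therefore carried from one core to the other in this assay, but only as an absence of any visible step, so this does not show that a step of measurable size would carry over in the same way.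

On these data alone, it remains open whether the readings would stay level with a carboxylic acid or an amine on either aromatic ring, or with a longer chain linking the two amine nitrogens.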